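Same Thiosemicarbazone, Now Drawn With a Fixed Double Bond

The source may report more compounds than this note shows. Statements on the series, on what has been measured and on what is new or still open speak of the compounds shown alone.

Measured so far, in a functional assay on MCF7 cells (Homo sapiens) for cytotoxicity, read by MTT assay, with a stated time of 48 h; on this read-out higher numbers stand for weaker inhibition and lower numbers for stronger inhibition:
- compound 1, `C/C(=N/NC(=S)Nc1ccccc1I)c1ccccn1`, gives 4.1 nM
- compound 2, `CC(=NNC(=S)Nc1ccccc1F)c1ccccn1`, gives 0.39 nM
- compound 3, `C/C(=N/NC(=S)Nc1ccc(Cl)cc1)c1ccccn1`, gives 8.49 nM

Compound 2 has the lowest number of the three in this assay, which on this read-out means the strongest inhibition. Its nearest neighbour is compound 1, whose number is higher by more than the usual scatter, and compound 3 sits further away still, also beyond the scatter. So among these three, compound 2 is the most potent.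

Compound 4, `C/C(=N/NC(=S)Nc1ccccc1F)c1ccccn1`, is the next compound to be measured in this assay. Its difference from compound 2 is the two compounds have the same atoms and bonds; at least one stereo element is drawn with a configuration in one of them and without one in the other: 1 of 1 stereo elements differ; a double bond is drawn without a configuration in compound 2 and Z in compound 4. In other words, nothing leaves and nothing enters; the drawing of compound 4 simply fixes a double bond geometry that compound 2 left open.

Within the data shown here, no step between two measured compounds is available to calibrate such a change. Since the atoms and bonds are identical, the expectation is that the step from compound 2 to compound 4 stays within the usual scatter, so the estimated step is a 1.2-fold higher number from compound 2 to compound 4 (0.06 log units; within the scatter), with no clear direction. On that basis compound 4 is expected to give about 0.45 nM in this assay, within a range from 0.15 nM to 1.4 nM.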

Compound 4, half-maximal inhibitory concentration: 0.39 nM
For compound 4 the middle estimate is 1.2-fold (0.06 log units) above the measured one; the range from low to high includes it.
By their numbers in this assay, from the lowest: compounds 2 and 4 (each within the scatter of the next); then compound 1; then compound 3.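

In this assay, fixing the double bond in the drawing makes no visible difference, with no change at the digits printed from compound 2 to compound 4 (within the scatter). The two records are separated only by a matter of depiction: the fact that one of compounds 2 and 4 is drawn with a defined configuration and the other without, at the place where they differ. The more useful gain is a clean halogen comparison: compound 1 and compound 2 differ both in the halogen and in how the double bond is drawn, whereas compound 4 shares its drawing with compound 1, which isolates fluoro in place of iodo on an aromatic carbon, with an 11-fold lower number from compound 1 to compound 4 (1.02 log units; beyond the scatter).

On these data alone, this single swap of one halogen for another shows a large step but no trend, and how a plain hydrogen, a methoxy group or a nitrile on that same aromatic carbon would compare with fluoro remains open. Also open is what a compound drawn with the opposite double bond geometry would give, as the undefined drawing of compound 2 does not tell which geometry or mixture of geometries lies behind its number.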